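A few compounds are considered here, and "the series" means these few. Any claim that something is new, unique, unknown or untested is made for them only; others in the source may bear on it.

Measured in a functional assay on Jurkat cells (Homo sapiens) for cytotoxicity, with a stated time of 72 h; a lower number here means that less compound is needed, a higher number that more compound is needed for the effect:
- Compound 1 `C=C[C@@](C)(/C=C/c1ccc(OS(=O)(=O)C(F)(F)F)cc1)CCC=C(C)C`: > 49000 nM
- Compound 2 `C=C[C@@](C)(/C=C/c1ccc(O)cc1)CCCO`: > 49000 nM
- Compound 3 `C=C[C@@](C)(/C=C/c1ccc(O)cc1)CC/C=C/C(=O)OCc1ccccc1`: > 49000 nM

All three readings are limits rather than numbers: the limit of > 49000 nM in this assay, at which 3 of the 3 values shown sit. Compound 2 therefore has no numerical position in the series; its > 49000 nM is a limit.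

Compound 4 `C=C[C@@](C)(/C=C/c1ccc(O)cc1)CC/C=C(\C)C=O` is the next case: 2-formylprop-1-en-1-yl in place of hydroxymethyl on a saturated chain carbon, three bonds along the chain from two double-bonded chain carbons. Here 2-formylprop-1-en-1-yl stands in place of hydroxymethyl on a saturated chain carbon, three bonds along the chain from two double-bonded chain carbons.

Within the data shown here, no measured step is available as a guide, so the expectation is loose. The expected change is an at least 1.4-fold lower number from compound 2 to compound 4 (0.14 log units; that floor lies within the scatter), a modest one toward less compound needed in this assay. Another limit remains quite possible. Compound 4 is estimated at 35000 nM, with an expected range of 12000 nM to 60000 nM.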

Compound 4, half-maximal effective concentration: > 49000 nM
Compound 4: no number, only a limit; the forecaster's own chance of this, stated with the estimate: 50%; middle value at least 1.4-fold (0.14 log units) away from the limit.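

No step can be read between compound 2 and compound 4, since both readings are limits rather than numbers: the limit of > 49000 nM in this assay, at which 4 of the 4 values shown sit.

The compounds shown leave open how far any of them lies beyond that limit, and whether any change in the chain shifts the reading at all.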